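Chloropurine benzyl chloride series: cytotoxicity on K562 cells

This account rests on a few compounds, and the source may have more. Where it says the series, first, only, none or still open, it means among the compounds named here.

Measured so far:
compound 1, `ClCc1cccc(Cn2cnc3c(Cl)nc(Cl)nc32)c1`: > 100000 nM
compound 2, `Nc1nc(Cl)c2ncn(Cc3ccccc3CCl)c2n1`: > 100000 nM
compound 3, `ClCc1ccc(Cn2cnc3ncnc(Cl)c32)cc1`: > 100000 nM

In a functional assay on K562 cells (Homo sapiens) for cytotoxicity, read by sulforhodamine B assay, with a stated time of 48 h (on this read-out lower numbers stand for higher toxicity in this test and higher numbers for lower toxicity in this test), compound 1 gives > 100000 nM, which is a limit of the test and not a number. Compound 2 gives > 100000 nM, likewise a limit. Compound 3 gives > 100000 nM, again only a limit. Compound 3 therefore sits at the limit of > 100000 nM in this assay, at which 3 of the 3 values shown sit, together with every other value shown; no ordering among the three can be read from these data.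

The next compound is compound 4, `ClCc1ccc(Cn2cnc3nc(Cl)nc(Cl)c32)cc1`. It differs from compound 3 by chloro in place of hydrogen on an aromatic carbon. Among the compounds with values here, no measured pair shows the effect of such a change in this assay. Compound 4 is expected to stay at the limit, an estimated step that the limit leaves unreadable from compound 3 to compound 4. The estimate for compound 4 is 150000 nM, with a range from 30000 nM to 500000 nM.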

Compound 4, concentration lethal to 50% of the cells: > 100000 nM
Compound 4 ended at the assay's limit; the forecaster's own chance of this, stated with the estimate: 80%; the middle value is on the limit's open side.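

Compound 4 gives > 100000 nM in this assay, which is a limit and not a number. Within the data shown here, no step from compound 3 to compound 4 can be read, because both values sit at the same limit: the limit of > 100000 nM in this assay, at which 4 of the 4 values shown sit.

The compounds shown leave open whether any member of the series reads inside the range of the test, and what chloro in place of hydrogen does there.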